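A few compounds are considered here, and "the series" means these few. Any claim that something is new, unique, unknown or untested is made for them only; others in the source may bear on it.

Measured so far:
Compound 1 `CCN1CCN(c2cc(C)c3cc(NC(=O)c4ccc[nH]4)ccc3n2)CC1`: 13200 nM
Compound 2 `Cc1cc(NCCN2CCN(C)CC2)nc2ccc(NC(=O)c3ccc(Cl)c(Cl)c3)cc12`: 2690 nM
Compound 3 `CCN(CC)CCNc1cc(C)c2cc(NC(=O)c3ccc(Cl)c(Cl)c3)ccc2n1`: 3710 nM

In a functional assay on SK-BR-3 cells (Homo sapiens) for antiproliferative activity, read by MTT assay, with a stated time of 72 h (a lower number here means a stronger inhibitor, a higher number a weaker inhibitor), compound 1 gives the highest of the three numbers; compounds 2 and 3 both give lower values, and between them the step of a 1.4-fold higher number from compound 2 to compound 3 (0.14 log units; within the scatter) is small. Compound 4 `CCN1CCN(c2cc(C)c3cc(NC(=O)c4ccc5ccccc5n4)ccc3n2)CC1` differs from compound 1 by quinolin-2-yl in place of 1H-pyrrol-2-yl on a carbonyl carbon. Among the measured compounds shown here, no measured step changes the group on the carbonyl carbon, so the only steps in hand, which alter the saturated chain, do not bear on this change. Compounds 2 and 3 show that lower numbers than that of compound 1 are reachable within this series, but they differ from compound 1 in more than one place. Compound 4 is therefore estimated with wide uncertainty at 5000 nM (range 1200 nM to 20000 nM), a step of a 2.6-fold lower number from compound 1 to compound 4 (0.42 log units; beyond the scatter) expected mainly from compound 1 sitting highest.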

Compound 4, half-maximal inhibitory concentration: 3760 nM
Estimate against measurement, compound 4: 1.3-fold (0.12 log units) above; low and high end bracket the measured number.
By their numbers in this assay, from the lowest: compounds 2, 3 and 4 (each within the scatter of the next); then compound 1.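

Among the compounds shown here, this is the first measured step at the carbonyl carbon, and in this assay it gives a 3.5-fold lower number from compound 1 to compound 4 (0.55 log units; beyond the scatter), so the number here responds to the group at this place. The change swaps a hydrogen-bond donor for an acceptor and enlarges the group in one move, so this single step cannot separate those differences. No measured evidence accounts for the lower number.

The compounds shown leave open whether a smaller group on the carbonyl carbon, such as phenyl or pyridin-2-yl, would give a number like that of compound 4.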